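Mirror-Image Urea Tested for Its Effect on Rice

A few compounds are considered here, and "the series" means these few. Any claim that something is new, unique, unknown or untested is made for them only; others in the source may bear on it.

Compound 1 `Cc1ccc(NC(=O)N[C@@H](C)c2ccccc2)cc1` and compound 2 `C[C@@H](NC(=O)Nc1ccc(C(C)(C)C)cc1)c1ccccc1` are both ureas built on the same shared core and differ in a single substituent on one of the aromatic rings. In an ADME assay on the whole organism with Oryza sativa as the target, tested at 0.1 uM (a lower number here means a stronger effect, a higher number a weaker effect of the compound at the concentration tested), compound 1 gives 100%. In this assay compound 2 gives 100%, so compound 2 stands level with compound 1 at the digits shown, with no change between the two beyond the scatter.

Compound 3 `C[C@H](NC(=O)Nc1ccc(C(C)(C)C)cc1)c1ccccc1` has not yet been measured. Its relation to compound 2 is this: the two compounds have the same atoms and bonds and differ only in configuration as drawn: 1 of 1 stereo elements differ; a stereocentre at a saturated chain carbon is drawn R in compound 2 and S in compound 3. Going by the values given here, no step between two measured compounds is known here that would show how swapping the configuration at this stereocentre changes the read-out. Both measured compounds sit at the same value in this assay, and nothing among them indicates that one configuration acts differently from the other. The step is therefore expected to be no change at the digits printed from compound 2 to compound 3 (within the scatter), meaning none beyond the scatter. For compound 3 the expected value in this assay is 100%, with a range from 85% to 100%.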

Compound 3, a percentage reported as activity, at one concentration (the size of the read-out at that concentration, not a potency): 100%
Beside the measured number, compound 3's estimate shows no gap at the digits printed; the range from low to high includes it.
By their numbers in this assay, from the lowest: compounds 1, 2 and 3 (each within the scatter of the next).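

In this assay, the stereocentre at the saturated chain carbon now has a direct test, and drawing it S rather than R gives no change at the digits printed from compound 2 to compound 3 (within the scatter). This comparison tests that one feature alone, with nothing else in the structures to account for a difference: the fact that compounds 2 and 3 differ only in the configuration as drawn. The other change now available, tert-butyl in place of methyl on an aromatic carbon, gives no change at the digits printed from compound 1 to compound 3 (within the scatter), so neither the configuration nor this exchange of groups separates these compounds in this assay.

Since all three compounds share one value, they do not show what would move the read-out at all, and a configuration that makes no difference here might still make one in a compound that has a stronger effect. On these data alone, it remains open whether a carboxylic acid or an amine on that aromatic carbon, or a longer chain in place of the methyl at the stereocentre, would change the number in this assay, and whether the R and S forms would then part ways.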